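Swapping the aryl group on a thiourea nitrogen

The compounds below may be only part of what the source reports. "The series", "measured", "known", "first", "only" and "open" are said of these compounds alone.

Compound 1 `N#Cc1ccc(NC(=S)N/N=C/c2ccc3ccccc3n2)cc1` is one of three compounds tested in a functional assay on SGC-7901 cells (Homo sapiens) for antiproliferative activity, read by sulforhodamine B assay, with a stated time of 72 h; on this read-out higher numbers stand for weaker inhibition and lower numbers for stronger inhibition. In this assay compound 1 gives 23700 nM, the highest of the two numbers recorded. Compound 3 `CN(C)C(=S)N/N=C/c1cc2cccnc2s1` gives 21400 nM, which sits within the usual scatter of the value for compound 1, so the two cannot be told apart on these data. Compound 2 `Cc1ccc(NC(=O)N/N=C/c2ccc3ccccc3n2)cc1` reaches only a limit of the assay, > 100000 nM, and so contributes no number; this is the limit (the limit of > 100000 nM in this assay, at which 1 of the 3 values shown sits).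

The unmeasured compound 4 `S=C(NCc1ccccc1)N/N=C/c1ccc2ccccc2n1` shares its core with compound 1 and differs in one place: benzyl in place of 4-cyanophenyl on an amide-type nitrogen. For the measured compounds named here, no measured pair shows the effect of this kind of exchange, so the expectation rests on the shared core alone. The step from compound 1 to compound 4 is estimated to be small, within the scatter in either direction, a 1.1-fold higher number from compound 1 to compound 4 (0.02 log units; within the scatter). Compound 4 is therefore expected to give about 25000 nM, somewhere between 8000 nM and 80000 nM.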

Compound 4, half-maximal inhibitory concentration: 53700 nM
Estimate against measurement, compound 4: 2.1-fold (0.33 log units) below; the range from low to high includes it.
By their numbers in this assay, from the lowest: compounds 3 and 1 (each within the scatter of the next); then compound 4. At a limit, above all of these: compound 2.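

For the compounds shown here, this is the only exchange at this position that can be read directly: on the amide-type nitrogen whose other neighbour is the thiocarbonyl carbon, benzyl in place of 4-cyanophenyl gives a 2.3-fold higher number from compound 1 to compound 4 (0.36 log units; beyond the scatter) in this assay, a modest step. The group on this nitrogen therefore does shift the read-out, and here 4-cyanophenyl goes with the lower number, meaning stronger inhibition, although this rests on a single pair. Nothing measured among these compounds explains why the number rises.

This one pair cannot separate the loss of the nitrile from the change of an aryl group to a benzyl group. Going by these compounds, how a plain phenyl, a phenyl carrying an amine, or a longer chain such as phenylethyl would behave on this nitrogen remains open.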